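The source may report more compounds than this note shows. Statements on the series, on what has been measured and on what is new or still open speak of the compounds shown alone.

Compound 1 `CS(=O)(=O)c1ccc(F)cc1NCC1=NCCN1` gives 1320 nM in an assay for binding affinity to Alpha-1B adrenergic receptor (Homo sapiens), read by radioligand binding (on this read-out lower numbers stand for stronger inhibition and higher numbers for weaker inhibition), the highest of the three numbers seen so far. Compound 3 `COc1ccc(SC)c(NCC2=NCCN2)c1` gives 692 nM, within the scatter of compound 1. Compound 2 `CSc1ccc(F)cc1NCC1=NCCN1` gives 40.7 nM, with a 32-fold lower number from compound 1 to compound 2 (1.51 log units; beyond the scatter). Compound 4 `CS(=O)(=O)c1ccc(Cl)cc1NCC1=NCCN1` differs from compound 1 by chloro in place of fluoro on an aromatic carbon. Among the compounds with values here, no measured step swaps one halogen for another: a 32-fold lower number from compound 1 to compound 2 (1.51 log units; beyond the scatter) concerns the sulfur group, and a 17-fold higher number from compound 2 to compound 3 (1.23 log units; beyond the scatter) replaces the same fluoro by methoxy, so neither bears directly on the change. Within the data shown here, with no close precedent, a step of no more than modest size in this assay is expected, in either direction. Compound 4 is therefore estimated at 1000 nM, between 300 nM and 3500 nM, that is a 1.3-fold lower number from compound 1 to compound 4 (0.12 log units; within the scatter).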

Compound 4, inhibition constant: 2950 nM
Beside the measured number, compound 4's estimate is 3.0-fold (0.47 log units) below it; low and high end bracket the measured number.
By their numbers in this assay, from the lowest: compound 2; then compounds 3 and 1 (each within the scatter of the next); then compound 4.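

In this assay, within the data shown here, chloro in place of fluoro, on the aromatic carbon para to a methylsulfonyl group, gives a 2.2-fold higher number from compound 1 to compound 4 (0.35 log units; beyond the scatter) as the first halogen exchange. With the methylsulfonyl group held fixed, the number at this position therefore depends on which halogen is present, and the step is modest. Nothing available explains the direction or size of this step.

From the compounds shown here alone, whether the same exchange moves the number the same way with methylsulfanyl in place of methylsulfonyl remains open. So does the response of this position to bromo, an amine, a carboxylic acid or a longer chain.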